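This account rests on a few compounds, and the source may have more. Where it says the series, first, only, none or still open, it means among the compounds named here.

Measured compounds:
Compound 1, `CC(C)(C)OC(=O)N1CCN(C(=O)c2cn(-c3ccc(C(F)(F)F)cc3)nn2)CC1`: 13.6 nM
Compound 2, `CC(C)(C)OC(=O)N1CCC(OC(=O)c2cn(-c3ccc(C(F)(F)F)cc3)nn2)CC1`: 10.4 nM
Compound 3, `CC(C)(C)OC(=O)N1CCC(OC(=O)c2cn(-c3ccc(C(F)(F)F)cc3Cl)nn2)CC1`: 11.1 nM

These three were tested in an assay on HEK293 cells for agonist activity at Glucose-dependent insulinotropic receptor (Homo sapiens), read by a luciferase reporter, with a stated time of 24 h; on this read-out higher numbers stand for an effect only at larger amounts of compound and lower numbers for an effect already at smaller amounts. Compound 2 holds the lowest of the three numbers, but the others lie close to it: the step of a 1.1-fold higher number from compound 2 to compound 3 (0.03 log units; within the scatter) is within the scatter, and the gap to compound 1 is within the scatter as well, so the three cannot be told apart on these data.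

Compound 4, `CC(C)(C)OC(=O)N1CCC(OC(=O)c2cn(-c3nc4ccccc4s3)nn2)CC1`, has not been measured. It differs from compound 2 in one place: 1,3-benzothiazol-2-yl in place of 4-(trifluoromethyl)phenyl on an aromatic nitrogen. Among the compounds with values here, the only single-point step among the measured compounds, a 1.1-fold higher number from compound 2 to compound 3 (0.03 log units; within the scatter), puts a chloro in place of a hydrogen on an aromatic carbon and left the number unchanged within the scatter; it says nothing about exchanging the whole aryl group for a different aromatic group. Within the data shown here, no measured step therefore bears directly on this change, and its direction cannot be read from the data. With the shared core unchanged and all three measured numbers close together, compound 4 is expected to fall in a similar region, estimated at 30 nM with a range of 5 nM to 250 nM, which corresponds to an expected step of a 2.9-fold higher number from compound 2 to compound 4 (0.46 log units; beyond the scatter). The range is kept wide since nothing measured covers this kind of exchange.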

Compound 4, half-maximal effective concentration: 8.17 nM
The estimate for compound 4 lay 3.7-fold (0.56 log units) above the measured number; the range from low to high includes it.
By their numbers in this assay, from the lowest: compounds 4, 2, 3 and 1 (each within the scatter of the next).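

In this assay, the exchange of the whole aromatic group gives a 1.3-fold lower number from compound 2 to compound 4 (0.10 log units; within the scatter). The earlier step changed only a single hydrogen to chloro on the aryl group, whereas this one shows that the aromatic nitrogen of the five-membered ring can carry 1,3-benzothiazol-2-yl instead of 4-(trifluoromethyl)phenyl with no readable change in the number. Nothing available here explains why these two different groups read alike.

Still open, from the compounds shown here alone, is how groups of another kind would read at this position, such as a saturated cyclohexyl ring, a plain methyl, or a phenyl carrying an amine or a carboxylic acid. Also open, going by these compounds, is whether 1,3-benzothiazol-2-yl would read the same way on the core of compound 1.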